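Swapping the Sulfonyl Group of Compound 3

This account rests on a few compounds, and the source may have more. Where it says the series, first, only, none or still open, it means among the compounds named here.

Measured in a functional assay on A2780 cells (Homo sapiens) for cytotoxicity, read by sulforhodamine B assay, with a stated time of 72 h; a lower number here means a stronger inhibitor, a higher number a weaker inhibitor:
Compound 1 `O=C(NCc1ccc(S(=O)(=O)c2ccccc2)cc1)c1cc2cnccc2[nH]1`: 18 nM
Compound 2 `O=S(=O)(c1ccccc1)c1ccc(CNS(=O)(=O)N2Cc3ccncc3C2)cc1`: > 2000 nM
Compound 3 `CCCn1cc(S(=O)(=O)c2ccc(CNC(=O)N3Cc4ccncc4C3)cc2)cn1`: 7.3 nM

Compound 2 gives > 2000 nM, which is a limit of the assay and not a number. Among the true numbers, compound 3 at 7.3 nM has the lowest, and its gap to compound 1 at 18 nM lies beyond the usual scatter of repeated measurements.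

The next compound to be tested is compound 4 `O=C(NCc1ccc(S(=O)(=O)C2CCN(C3COC3)CC2)cc1)N1Cc2ccncc2C1`. It carries 1-(oxetan-3-yl)piperidin-4-yl in place of 1-propyl-1H-pyrazol-4-yl on a sulfonyl sulfur. Among the compounds with values here, no measured pair shows what a change at this place does, and no measured compound carries the entering group. The expectation therefore starts from compound 3 at 7.3 nM and allows only a small move towards a higher number in this assay, probably within the scatter. The expected step is a 1.6-fold higher number from compound 3 to compound 4 (0.22 log units; within the scatter).

For compound 4 the estimate is 12 nM, with an expected range of 3 nM to 50 nM.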

Compound 4, half-maximal inhibitory concentration: 7.4 nM
Compound 4: the middle estimate sits 1.6-fold (0.21 log units) above what was measured; the range from low to high includes it.
By their numbers in this assay, from the lowest: compounds 3 and 4 (each within the scatter of the next); then compound 1. At a limit, above all of these: compound 2.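

In this assay, the change on the sulfonyl sulfur gives a 1.0-fold higher number from compound 3 to compound 4 (0.01 log units; within the scatter). Within the data shown here, this is the first measured pair at this place, and it shows that the value does not depend on an aromatic group there: 1-(oxetan-3-yl)piperidin-4-yl, with two non-aromatic rings and 10 heavy atoms, matches 1-propyl-1H-pyrazol-4-yl, with one five-membered aromatic ring and 8 heavy atoms. Nothing measured here accounts for this match.

As far as these compounds go, it remains open whether a group ending in a carboxylic acid or a primary amine would also be accepted on this sulfur. From the compounds shown here alone, it is also open what a piperidin-4-yl carrying a plain methyl in place of oxetan-3-yl would give, so the share of the oxetane ring in this result cannot be told.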